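The source may hold more compounds than are shown below. What is called first, only, known or untested is meant among the compounds shown, and "the series" means these compounds.

Measured compounds:

- Compound 1, `O=C(NO)c1cnc(N2CCN(S(=O)(=O)c3ccc4ccccc4c3)CC2)s1`, gives 2000 nM in a functional assay on MCF7 cells (Homo sapiens) for antiproliferative activity; a higher number here means a weaker inhibitor of growth, a lower number a stronger inhibitor of growth.
- Compound 2, `O=C(NO)c1cnc(N2CCN(S(=O)(=O)c3ccc(-c4ccccc4)cc3)CC2)s1`, gives 1800 nM in this assay.
- Compound 3, `O=C(/C=C/c1cnc(N2CCN(S(=O)(=O)c3ccc(OC(F)(F)F)cc3)CC2)s1)NO`, gives 6000 nM in this assay.

Compound 3 carries the highest number of the three, so it is the weakest inhibitor of growth in this set. Its gap to compound 1 and its gap to compound 2 both lie beyond the scatter. Compound 1 and compound 2 sit within the scatter of each other, so no order between them is claimed.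

Compound 4, `O=C(/C=C/c1cnc(N2CCN(S(=O)(=O)c3ccc(F)cc3)CC2)s1)NO`, is not yet measured in this assay. It differs from compound 3 in one place: fluoro in place of trifluoromethoxy on an aromatic carbon. Within the data shown here, no pair among the measured compounds shows this change, so no measured step guides the expectation. The shared core and the hydroxamic acid side of compound 3 remain unchanged. For compound 4 in this assay the estimated step of a 1.3-fold higher number from compound 3 to compound 4 (0.12 log units; within the scatter) is expected to be small and not clearly beyond the scatter, with the number most likely staying near that of compound 3 or drifting somewhat higher. Compound 4 is therefore estimated at 8000 nM, with a range from 3000 nM to 22000 nM.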

Compound 4, concentration for 50% growth inhibition: 2500 nM
Estimate against measurement, compound 4: 3.2-fold (0.51 log units) above; measured number below the stated range.
By their numbers in this assay, from the lowest: compounds 2, 1 and 4 (each within the scatter of the next); then compound 3.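

Fluoro in place of trifluoromethoxy on an aromatic carbon para to a large group gives a 2.4-fold lower number from compound 3 to compound 4 (0.38 log units; beyond the scatter) in this assay, the first measured step at this position. The position therefore responds to a change of substituent, and trifluoromethoxy is not required for the growth inhibition seen here, since the group of 1 heavy atom gives the lower number in this single pair. No measurement on hand bears on the origin of this step.

One pair cannot show whether the number follows the size of the group or something specific to fluoro; chloro, methoxy or plain hydrogen at the same place would help separate these. On these data alone, whether the same exchange gives a similar step on a compound without the alkene link, with the hydroxamic acid directly on the shared core, also stays open.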